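Swapping the ring on the sulfonyl: morpholine to hydroxypiperidine

The compounds below may be only part of what the source reports. "The series", "measured", "known", "first", "only" and "open" are said of these compounds alone.

Measured so far:
compound 1 `O=C(NCc1ccc(S(=O)(=O)C2CCC(F)(F)CC2)cc1)N1Cc2ccncc2C1` gives 78 nM in an assay on isolated protein for inhibition of Nicotinamide phosphoribosyltransferase (Homo sapiens), read by mass spectrometry, with stated times of 15 min and 30 min; a lower number here means a stronger inhibitor, a higher number a weaker inhibitor;
compound 2 `O=C(NCc1ccc(S(=O)(=O)N2CCOCC2)cc1)N1Cc2ccncc2C1` gives 71 nM in this assay.

Compound 2 holds the lowest of the two numbers, with compound 1 closest to it; the step of a 1.1-fold lower number from compound 1 to compound 2 (0.04 log units; within the scatter) lies within the scatter. Compound 3 `O=C(NCc1ccc(S(=O)(=O)N2CCC(O)CC2)cc1)N1Cc2ccncc2C1` differs from compound 2 by 4-hydroxypiperidin-1-yl in place of morpholin-4-yl on a sulfonyl sulfur. Within the data shown here, the one step that bears on this change is at the same sulfonyl position, and it was a 1.1-fold lower number from compound 1 to compound 2 (0.04 log units; within the scatter). A step of similar size, not beyond the scatter, is therefore expected from compound 2 to compound 3, namely a 1.0-fold lower number from compound 2 to compound 3 (0.01 log units; within the scatter). Compound 3 is estimated at 70 nM in this assay, within 30 nM to 160 nM.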

Compound 3, half-maximal inhibitory concentration: 44 nM
For compound 3 the middle estimate is 1.6-fold (0.20 log units) above the measured one, and the stated range covers the measured number.
By their numbers in this assay, from the lowest: compounds 3, 2 and 1 (each within the scatter of the next).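

Compared with morpholin-4-yl, 4-hydroxypiperidin-1-yl adds a hydrogen-bond donor on the sulfonyl sulfur, and this assay shows a 1.6-fold lower number from compound 2 to compound 3 (0.21 log units; within the scatter). The comparison with 4,4-difluorocyclohexyl shows a 1.8-fold lower number from compound 1 to compound 3 (0.25 log units; within the scatter). All three rings thus read alike here, even with the donor present, and nothing available explains this result.

As far as these compounds go, it remains open whether any group on this sulfonyl sulfur can move the number beyond the scatter. A carboxylic acid or a primary amine carried on the ring would test this.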